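This account rests on a few compounds, and the source may have more. Where it says the series, first, only, none or still open, it means among the compounds named here.

Measured so far: compound 1 `CNC(=O)c1nc(-c2cc(OC)c(OC)c(OC)c2)n(-c2ccc(OC)cc2)n1` with 74%; compound 2 `COc1ccc(-n2nc(C(=O)Nc3ccc(C(=O)O)cc3)nc2-c2cc(OC)c(OC)c(OC)c2)cc1` with 57%.

In a functional assay on the whole organism for inhibition, with Rattus norvegicus as the target, read by paw edema, with stated times of 30 min and 2 h, at a dose of 0.28 mmol/kg by the oral route (a higher number here means more inhibition at the dose given (going by the name of the read-out), a lower number less inhibition), compound 2 gives 57%, the lower of the two numbers, while compound 1 gives 74%. Compound 3 `COc1ccc(-n2nc(C(=O)Nc3ccc(O)cc3)nc2-c2cc(OC)c(OC)c(OC)c2)cc1` differs from compound 2 by hydroxy in place of carboxy on an aromatic carbon. Within the data shown here, no measured step touches this substituent; the single step known, a number 17 percentage points lower from compound 1 to compound 2 (beyond the scatter), exchanges the whole amide substituent and bears only indirectly. The amide substituent of compound 3 remains an aryl group, so no step beyond the scatter is expected, an estimated a number 5 percentage points higher from compound 2 to compound 3 (within the scatter). Compound 3 is therefore expected at 62%, range 45% to 78%.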

Compound 3, a percentage reported as inhibition, in the whole organism at one dose (the size of the read-out at that dose, not a potency): 35%
Estimate against measurement, compound 3: 27 percentage points above; measured number outside the range, below it.
By their numbers in this assay, from the lowest: compound 3; then compound 2; then compound 1.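

Aryl amides do not read alike in this assay: with hydroxy in place of carboxy para to a large group, the result is a number 22 percentage points lower from compound 2 to compound 3 (beyond the scatter), so this substituent on the aromatic ring counts in its own right. Against the methyl amide, 4-hydroxyphenyl gives a number 39 percentage points lower from compound 1 to compound 3 (beyond the scatter). Nothing at hand explains these steps.

Open, from the compounds shown here alone, is where an amine on that aromatic carbon would fall relative to compound 2 and compound 3. Also open, going by these compounds, is whether a longer chain in place of methyl on the amide nitrogen would stay level with compound 1.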